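The compounds below may be only part of what the source reports. "The series", "measured", "known", "first", "only" and "open" are said of these compounds alone.

Measured compounds:
compound 1 `CCOC(=O)c1sc2nc(SC)nc(-c3cccc(OC)c3)c2c1N` — 4.2%
compound 2 `COc1cccc(-c2nc(SC)nc3sc(C(=O)N(C)C(C)(C)C)c(N)c23)c1` — 47.8%

Among the compounds with values here, in a functional assay on HEK293 cells for agonist activity at lutropin-choriogonadotropic hormone receptor (Homo sapiens), read by cAMP accumulation (a higher number here means a larger maximal response, a lower number a smaller maximal response), compound 2 stands highest of the two numbers, and the only measured step, a number 43.6 percentage points higher from compound 1 to compound 2 (beyond the scatter), is large. Compound 3 `COc1cccc(-c2nc(SC)nc3sc(C(=O)NN)c(N)c23)c1` differs from compound 2 at the same carbonyl carbon: aminoamino in place of methyl(tert-butyl)amino on a carbonyl carbon. Within the data shown here, no measured step concerns this pair of groups; the single step at this position involves a different exchange, so it gives only a rough scale of how much the carbonyl substituent can move the response. The expected step is a number 27.8 percentage points lower from compound 2 to compound 3 (beyond the scatter), downward but with wide uncertainty. Compound 3 is estimated at 20%, with a range from 2% to 50%.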

Compound 3, largest response reached (reported as efficacy), in percent of the reference or control that the assay uses: 8.5%
Beside the measured number, compound 3's estimate is 11.5 percentage points above it; the range from low to high includes it.
By their numbers in this assay, from the lowest: compounds 1 and 3 (each within the scatter of the next); then compound 2.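

In this assay, aminoamino in place of methyl(tert-butyl)amino on a carbonyl carbon gives a number 39.3 percentage points lower from compound 2 to compound 3 (beyond the scatter) and shows that replacing ethoxy does not by itself raise the response. Aminoamino in place of ethoxy gives a number 4.3 percentage points higher from compound 1 to compound 3 (within the scatter) and is not told apart from it, so among these three groups only methyl(tert-butyl)amino stands out. No evidence on the cause of this difference is available.

Still open, as far as these compounds go, is whether the higher response depends on the tert-butyl group, the methyl group or both. Tert-butylamino and dimethylamino on the same carbonyl carbon would separate these.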